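A few compounds are considered here, and "the series" means these few. Any claim that something is new, unique, unknown or untested is made for them only; others in the source may bear on it.

Measured compounds:
compound 1, `COC(C)(C)[C@@H](O)C(=O)N1[C@H](C(=O)NCc2cc(Cl)ccc2-n2cnnn2)C[C@@H]2C[C@@H]21`, 1000 nM
compound 2, `O=C(NCc1cc(Cl)ccc1-n1cnnn1)[C@@H]1C[C@@H]2C[C@@H]2N1C(=O)[C@H](O)c1cccc(Cl)c1`, 1000 nM
compound 3, `O=C(NCc1cc(Cl)ccc1-n1cnnn1)[C@@H]1C[C@@H]2C[C@@H]2N1C(=O)[C@H](O)CC1CC1`, 1700 nM

In a functional assay on a cell-free system (plasma, Homo sapiens), with a stated time of 3 min (a higher number here means a weaker inhibitor, a lower number a stronger inhibitor), compound 3 gives 1700 nM, the highest of the three numbers, but its steps to the other two are within the scatter: a 1.7-fold higher number from compound 1 to compound 3 (0.23 log units; within the scatter) and a 1.7-fold higher number from compound 2 to compound 3 (0.23 log units; within the scatter). The remaining step, no change at the digits printed from compound 1 to compound 2 (within the scatter), is likewise within the scatter, so the three measured compounds do not separate in this assay.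

Compound 4, `CC(C)(C)C[C@@H](O)C(=O)N1[C@H](C(=O)NCc2cc(Cl)ccc2-n2cnnn2)C[C@@H]2C[C@@H]21`, has not yet been measured. It differs from compound 3 as follows: tert-butyl in place of cyclopropyl on a saturated chain carbon, two bonds along the chain from a carbonyl carbon and an oxygen on a saturated carbon. Among the compounds with values here, no measured step changes cyclopropyl to tert-butyl at this place; the steps that touch the same chain, a 1.7-fold higher number from compound 1 to compound 3 (0.23 log units; within the scatter) and a 1.7-fold higher number from compound 2 to compound 3 (0.23 log units; within the scatter), exchange the whole group on the carbon bearing the hydroxyl and stayed within the scatter, and so did no change at the digits printed from compound 1 to compound 2 (within the scatter). On that basis no step beyond the scatter is expected from compound 3 to compound 4 in this assay, in either direction, and the expected step of a 1.1-fold lower number from compound 3 to compound 4 (0.05 log units; within the scatter) is small.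

Compound 4 is therefore estimated at 1500 nM in this assay, with a range from 700 nM to 3500 nM.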

Compound 4, half-maximal inhibitory concentration: 570 nM
Beside the measured number, compound 4's estimate is 2.6-fold (0.42 log units) above it; the measured number lies below the stated range.
By their numbers in this assay, from the lowest: compounds 4, 1, 2 and 3 (each within the scatter of the next, the first and the last beyond it).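

Among the steps shown in this assay, a 3.0-fold lower number from compound 3 to compound 4 (0.47 log units; beyond the scatter) is the first to pass beyond the scatter, so the group on a saturated chain carbon, two bonds along the chain from a carbonyl carbon and an oxygen on a saturated carbon, can move this read-out even though the earlier exchanges did not separate the compounds. The effect is modest and does not set the new compound apart from the whole set: a 1.8-fold lower number from compound 2 to compound 4 (0.24 log units; within the scatter) and a 1.8-fold lower number from compound 1 to compound 4 (0.24 log units; within the scatter), so neopentyl does not separate from 3-chlorophenyl or 1-methoxy-1-methylethyl on the carbon bearing the hydroxyl. Within the data shown here, nothing measured here accounts for the one step beyond the scatter.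

The compounds shown leave open whether that step follows the loss of the three-membered ring or the change from cyclopropyl to tert-butyl as a whole, a question that cyclobutyl or isopropyl at the same place would address. They also leave open how an amine, a carboxylic acid or a longer chain at this place would read in this assay.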